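A few compounds are considered here, and "the series" means these few. Any claim that something is new, unique, unknown or untested is made for them only; others in the source may bear on it.

Compound 1 `Nc1scc(CN2CCN(c3ccc([N+](=O)[O-])cc3)CC2)c1C(=O)c1ccc(Cl)cc1` carries a 4-nitrophenyl group on a ring nitrogen. In an assay on CHO cells for displacement of a labelled ligand from adenosine receptor A1 (Homo sapiens), read by scintillation counting, with a stated time of 120 min, tested at 10 uM (on this read-out higher numbers stand for more inhibition at the one concentration tested (going by the name of the read-out) and lower numbers for less inhibition), compound 1 gives 1%, and compound 2 `Nc1scc(CN2CCN(c3cccnc3)CC2)c1C(=O)c1ccc(Cl)cc1` gives 0%, so the two stand together and the step of a number 1 percentage points lower from compound 1 to compound 2 (within the scatter) shows no separation. Compound 3 `Nc1scc(CN2CCN(c3ccccc3F)CC2)c1C(=O)c1ccc(Cl)cc1` differs from compound 1 in one place: 2-fluorophenyl in place of 4-nitrophenyl on an amine nitrogen in a ring. Among the measured compounds shown here, the only measured step, a number 1 percentage points lower from compound 1 to compound 2 (within the scatter), also exchanged the group on that ring nitrogen without moving the read-out, so nothing beyond the scatter is expected in this assay here. Compound 3 is therefore expected to give 1%, between -8% and 10%, a step of no change at the digits printed from compound 1 to compound 3 (within the scatter).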

Compound 3, a percentage reported as inhibition, at one concentration (the size of the read-out at that concentration, not a potency): 4%
Compound 3: middle estimate off by 3 percentage points, on the low side; measured number inside the range.
By their numbers in this assay, from the lowest: compounds 2, 1 and 3 (each within the scatter of the next).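

In this assay, placing 2-fluorophenyl on the ring nitrogen gives a number 3 percentage points higher from compound 1 to compound 3 (within the scatter), and the same group set against pyridin-3-yl gives a number 4 percentage points higher from compound 2 to compound 3 (within the scatter). This position has now carried a third aromatic ring, one without the hydrogen-bond acceptors counted on 4-nitrophenyl, and all three compounds remain within the scatter of one another. No available evidence accounts for this. Going by these compounds, all three groups are six-membered aromatic rings, so the effect of a longer chain ending in an amine or a carboxylic acid on that nitrogen remains open. On these data alone, whether any group here can give inhibition beyond the scatter also remains open.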